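Phenyl in Place of 1,2-Oxazol-5-yl

This account rests on a few compounds, and the source may have more. Where it says the series, first, only, none or still open, it means among the compounds named here.

In a physicochemical assay for lipophilicity, at pH 7.4 (a higher number here means a more lipophilic compound, a lower number a more polar compound), compound 1 (`CC(C)Oc1ccc(-c2nnc(-n3cncn3)s2)cc1Cl`) gives 6.18 and compound 2 (`CC(C)Oc1ccc(-c2nnc(-c3ccno3)s2)cc1Cl`) gives 6.93 as the higher of the two numbers. Compound 3 (`CC(C)Oc1ccc(-c2nnc(-c3ccccc3)s2)cc1Cl`) carries phenyl in place of 1,2-oxazol-5-yl on an aromatic carbon. Among the compounds with values here, the only measured step that bears on this, 1,2-oxazol-5-yl in place of 1H-1,2,4-triazol-1-yl, gave a number 0.75 log units higher from compound 1 to compound 2 (beyond the scatter) and so a further rise of similar size is expected in this assay with a ring of carbon only. The expected step is a number 0.67 log units higher from compound 2 to compound 3 (beyond the scatter) in size and direction. For compound 3 the estimated value is 7.6 with a range from 7.1 to 8.1 at its two ends.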

Compound 3, distribution coefficient: 8.65
Compound 3: middle estimate off by 1.05 log units, on the low side; the measured number lies above the stated range.
By their numbers in this assay, from the lowest: compound 1; then compound 2; then compound 3.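

In this assay, this position proves highly sensitive to which aromatic ring it carries: phenyl, a ring of carbon only with no hydrogen-bond acceptors, gives a number 1.72 log units higher from compound 2 to compound 3 (beyond the scatter), a large step where the earlier change was modest. Across the three compounds the full change is a number 2.47 log units higher from compound 1 to compound 3 (beyond the scatter), so the rise continues with each replacement and the last replacement contributes the larger part.

Nothing shown explains why the step to phenyl is so large. Also open, from the compounds shown here alone, is how a phenyl ring carrying an amine or a carboxylic acid would fall.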